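Swapping Imidazole for Piperidine on the Side Chain

The source may report more compounds than this note shows. Statements on the series, on what has been measured and on what is new or still open speak of the compounds shown alone.

Measured so far:
- compound 3 `Cn1cc(C2=C(c3nn(CCCn4ccnc4)c4ncccc34)C(=O)NC2=O)c2ccccc21`: 13800 nM
- compound 2 `Cn1cc(C2=C(c3nn(CCCCn4ccnc4)c4ncccc34)C(=O)NC2=O)c2ccccc21`: 31800 nM
- compound 1 `Cn1cc(C2=C(c3nn(CCCN4CCCCC4)c4ncccc34)C(=O)N(c3ccccn3)C2=O)c2ccccc21`: > 100000 nM

In a functional assay on K562 cells (Homo sapiens) for antiproliferative activity, read by MTT assay, with a stated time of 48 h (on this read-out lower numbers stand for stronger inhibition and higher numbers for weaker inhibition), compound 3 gives the lowest of the two numbers shown, with compound 2 nearest (a 2.3-fold lower number from compound 2 to compound 3 (0.36 log units; beyond the scatter)). Compound 1 reaches only the limit of > 100000 nM in this assay, at which 1 of the 3 values shown sits, rather than a number. Compound 4 `Cn1cc(C2=C(c3nn(CCCN4CCCCC4)c4ncccc34)C(=O)NC2=O)c2ccccc21` differs from compound 3 in one place: piperidin-1-yl in place of 1H-imidazol-1-yl on a saturated chain carbon, three bonds along the chain from an aromatic nitrogen. No measured step covers this exchange; the one step shown concerns chain length, not the ring. Compound 1 carries the same piperidinyl chain but also a different imide nitrogen substituent, so it offers only a loose hint. Compound 4 is therefore expected to be a 1.6-fold higher number from compound 3 to compound 4 (0.20 log units; within the scatter), giving an estimate of 22000 nM, within 6000 nM and 90000 nM.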

Compound 4, half-maximal inhibitory concentration: 5960 nM
For compound 4 the middle estimate is 3.7-fold (0.57 log units) above the measured one, outside the stated range (below it).
By their numbers in this assay, from the lowest: compound 4; then compound 3; then compound 2. At a limit, above all of these: compound 1.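

Exchanging 1H-imidazol-1-yl for piperidin-1-yl on this chain gives a 2.3-fold lower number from compound 3 to compound 4 (0.36 log units; beyond the scatter), and set against the longer imidazole chain the exchange gives a 5.3-fold lower number from compound 2 to compound 4 (0.73 log units; beyond the scatter). Replacing pyridin-2-yl with hydrogen on the amide-type nitrogen in a ring gives an at least 16-fold lower number from compound 1 to compound 4 (1.22 log units; beyond the scatter), so the 3-(piperidin-1-yl)propyl chain alone does not bring the weak result of compound 1. The entry for compound 1 is a limit, not a number: the limit of > 100000 nM in this assay, at which 1 of the 4 values shown sits.

Still open, going by these compounds, is whether a morpholine ring or open-chain diethylamine on the same chain would match piperidin-1-yl. Also open, on these data alone, is whether a longer chain carrying piperidin-1-yl would give a higher number, as it does with imidazole.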